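The source may report more compounds than this note shows. Statements on the series, on what has been measured and on what is new or still open speak of the compounds shown alone.

Of the compounds shown here, two have been measured so far, compound 1 `CCCCCCCCCCc1cccc(N2CCNCC2)n1` and compound 2 `CCCCSc1cccc(N2CCNCC2)n1`, both in a functional assay on the whole organism with Mus musculus as the target, in the maximal electroshock model, with a stated time of 120 min; on this read-out higher numbers stand for an effect only at larger amounts of compound and lower numbers for an effect already at smaller amounts. In this assay compound 1 gives 30 mg/kg, whereas compound 2 gives 100 mg/kg, the higher of the two numbers; the gap between compound 2 and compound 1 lies beyond the usual scatter of such measurements. Going by the values given here, no pair of measured compounds differing in a single place exists, so no step can be quoted.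

Compound 3 `CCCCCc1cccc(N2CCNCC2)n1` has not yet been measured. It differs from compound 2 in one place, on the aromatic carbon next to the ring nitrogen: pentyl in place of butylsulfanyl on an aromatic carbon. Among the compounds with values here, since the two measured compounds give no directly comparable step, the size of this change can only be guessed. A small step in this assay, within the scatter and if anything toward a lower number, is expected, amounting to a 1.4-fold lower number from compound 2 to compound 3 (0.15 log units; within the scatter). For compound 3 the estimated value in this assay is 70 mg/kg, with a plausible range from 30 mg/kg to 150 mg/kg.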

Compound 3, minimum effective dose: 10 mg/kg
Compound 3: the middle estimate sits 7.0-fold (0.85 log units) above what was measured; the whole stated range lies above it.
By their numbers in this assay, from the lowest: compound 3; then compound 1; then compound 2.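

Pentyl and butylsulfanyl have the same count of heavy atoms, yet on this aromatic carbon next to the ring nitrogen the exchange is far from neutral: in this assay pentyl in place of butylsulfanyl gives a 10-fold lower number from compound 2 to compound 3 (1.00 log units; beyond the scatter). The position therefore responds to the atom swapped within the chain, with a carbon entering where the sulfur left, and not only to the size of the group. The chain length matters too, since hydrogen in place of pentyl on a saturated chain carbon, five bonds along the chain from an aromatic carbon, gives a 3.0-fold lower number from compound 1 to compound 3 (0.48 log units; beyond the scatter), so in this pair the longer chain of compound 1 does not carry the lower number. No measurement shown here accounts for either step.

As far as these compounds go, with only these chains at this position, it remains open whether the number keeps falling or turns upward with a chain between those of compound 3 and compound 1, such as an octyl group. Equally open, from the compounds shown here alone, is how a butoxy group, or a chain ending in an amine or a carboxylic acid, would behave on the same carbon.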